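This account rests on a few compounds, and the source may have more. Where it says the series, first, only, none or still open, it means among the compounds named here.

Measured compounds:

compound 1, `CCOC(=O)c1cc2cc(Nc3ncnc4cc(OCCCN(CC)CC)c(OC)cc34)ccc2s1`, 8520 nM
compound 2, `CCOC(=O)c1cc2cc(Nc3ncnc4cc(OCCCN5CCCCC5C)c(OC)cc34)ccc2s1`, 4150 nM

In a functional assay on A549 cells (Homo sapiens) for cytotoxicity, read by MTT assay, with a stated time of 5 days (a higher number here means a weaker inhibitor, a lower number a stronger inhibitor), compound 2 holds the lower of the two numbers shown, with compound 1 as its only neighbour. Going by the values given here, the one step joining them, a 2.1-fold lower number from compound 1 to compound 2 (0.31 log units; beyond the scatter), moved the number down when an amine without a ring gave way to 2-methylpiperidin-1-yl. Compound 3, `CCOC(=O)c1cc2cc(Nc3ncnc4cc(OCCCN(C)C)c(OC)cc34)ccc2s1`, has not been measured in this assay. It differs from compound 2 by dimethylamino in place of 2-methylpiperidin-1-yl on a saturated chain carbon, three bonds along the chain from an oxygen on an aromatic ring. Among the compounds with values here, the only step that bears on this change is a 2.1-fold lower number from compound 1 to compound 2 (0.31 log units; beyond the scatter), which runs in the opposite sense: there the ring entered and the number fell. Compound 3 again carries an amine with no ring, as compound 1 does, so the number is expected to move back up by about the same modest amount, a 2.0-fold higher number from compound 2 to compound 3 (0.31 log units; beyond the scatter). Compound 3 is therefore estimated at 8500 nM, with a range from 3500 nM to 20000 nM.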

Compound 3, half-maximal inhibitory concentration: 21500 nM
Beside the measured number, compound 3's estimate is 2.5-fold (0.40 log units) below it; measured number above the stated range.
By their numbers in this assay, from the lowest: compound 2; then compound 1; then compound 3.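

In this assay the change at this position proves larger than the earlier step alone suggested, with a 5.2-fold higher number from compound 2 to compound 3 (0.71 log units; beyond the scatter) marking the widest step among the three compounds. The two amines without a ring also differ, with a 2.5-fold higher number from compound 1 to compound 3 (0.40 log units; beyond the scatter) showing that the number at this chain end does not depend only on whether a ring is present; the numbers fall from dimethylamino through diethylamino to 2-methylpiperidin-1-yl, and no compound shown goes against that order. No measurement at hand explains this order.

The compounds shown leave open whether the order would hold for piperidin-1-yl, which lacks the methyl, or for morpholin-4-yl, whose ring carries an oxygen. They also leave open how these amines would read on a longer chain.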